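The source may report more compounds than this note shows. Statements on the series, on what has been measured and on what is new or still open speak of the compounds shown alone.

Compound 1: `CCCS(=O)(=O)c1ccc(C)c(C#Cc2cc(C#N)ccc2OCC(=O)O)c1` gives 7 nM
Compound 2: `CCCS(=O)(=O)c1cccc(C#Cc2cc(Cl)ccc2OCC(=O)O)c1` gives 9 nM
Compound 3: `CC(C)c1ccc(S(C)(=O)=O)cc1C#Cc1cc(C#N)ccc1OCC(=O)O` gives 12 nM

These three compounds share a core and were measured in an assay on CHO cells for displacement of a labelled ligand from prostaglandin D2 receptor 2 (Homo sapiens), read by scintillation counting; on this read-out higher numbers stand for weaker inhibition and lower numbers for stronger inhibition. On those numbers compound 2 stands second highest of the three, but its gaps to compound 1 and to compound 3 both lie within the usual scatter, so the three cannot be told apart.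

Compound 4, `CN(C)C(=O)c1cccc(C#Cc2cc(Cl)ccc2OCC(=O)O)c1`, has not yet been measured. It differs from compound 2 by dimethylcarbamoyl in place of propylsulfonyl on an aromatic carbon. For the measured compounds named here, no measured pair shows what such an exchange does here, so any expectation rests on the change alone. Compound 4 is expected to give a higher number than compound 2, that is, weaker inhibition, by a step estimated as a 4.4-fold higher number from compound 2 to compound 4 (0.65 log units; beyond the scatter). The value for compound 4 is estimated at 40 nM, expected to fall between 10 nM and 200 nM.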

Compound 4, inhibition constant: 52 nM
Compound 4: the middle estimate sits 1.3-fold (0.11 log units) below what was measured, within the range that was stated.
By their numbers in this assay, from the lowest: compounds 1, 2 and 3 (each within the scatter of the next); then compound 4.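

For the compounds shown here, replacing propylsulfonyl with dimethylcarbamoyl on this aromatic carbon gives, in this assay, a 5.8-fold higher number from compound 2 to compound 4 (0.76 log units; beyond the scatter), the first single-place change that can be read in this set. The group at this position therefore matters, and for this pair the sulfone-bearing compound 2 is the stronger inhibitor. Nothing in the data explains why the step occurs.

On these data alone, whether a sulfonamide, an amine or a carboxylic acid at this carbon would behave more like propylsulfonyl or dimethylcarbamoyl remains open. So does whether the same exchange would give a similar step on compounds carrying a nitrile instead of chlorine.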